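The compounds below may be only part of what the source reports. "The series", "measured", "known", "first", "only" and "open" are said of these compounds alone.

In a functional assay on MDA-MB-231 cells (Homo sapiens) for antiproliferative activity, read by MTT assay, with a stated time of 24 h (on this read-out lower numbers stand for stronger inhibition and higher numbers for weaker inhibition), compound 1 `Cc1ccccc1NNC(=O)c1ccccc1NS(=O)(=O)c1cnc(O)nc1O` reads > 20000 nM, which is a limit of the assay and not a number. For the measured compounds named here, compound 2 `O=C(NNC(=O)c1ccccc1NS(=O)(=O)c1cnc(O)nc1O)c1ccccc1Cl` gives 8310 nM, the only true number so far. Going by the values given here, the single measured change, an at least 2.4-fold lower number from compound 1 to compound 2 (0.38 log units; beyond the scatter), put (2-chlorophenyl)carbonyl in place of 2-methylphenyl on an amine nitrogen. Compound 3 `O=C(NNC(=O)c1ccccc1NS(=O)(=O)c1cnc(O)nc1O)c1cccc(Cl)c1` instead carries 3-chlorophenyl in place of 2-chlorophenyl on a carbonyl carbon. Among the compounds with values here, no measured step tests this swap, so no clear shift in either direction is expected, and the expected result is a 1.1-fold higher number from compound 2 to compound 3 (0.03 log units; within the scatter). For compound 3 the estimate is 9000 nM, with an expected range of 3500 nM to 20000 nM.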

Compound 3, half-maximal inhibitory concentration: 4420 nM
Estimate against measurement, compound 3: 2.0-fold (0.31 log units) above; measured number inside the range.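

With 3-chlorophenyl in place of 2-chlorophenyl on a carbonyl carbon, this assay shows a 1.9-fold lower number from compound 2 to compound 3 (0.27 log units; within the scatter), so these two chlorine placements cannot be told apart here. The (3-chlorophenyl)carbonyl group in place of 2-methylphenyl on an amine nitrogen gives an at least 4.5-fold lower number from compound 1 to compound 3 (0.65 log units; beyond the scatter), so the earlier step now has a second example. The size of that step rests on compound 1, whose reading is a limit of the assay and not a number: the limit of > 20000 nM in this assay, at which 1 of the 3 values shown sits.

The compounds shown leave open whether 4-chlorophenyl or plain phenyl on the same carbonyl carbon would read differently, and so whether the chlorine itself matters.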